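The compounds below may be only part of what the source reports. "The series", "measured", "known", "first", "only" and "open" are said of these compounds alone.

The measured compounds are compound 1 `O=[N+]([O-])c1ncn(CCNS(=O)(=O)Cc2ccccc2)n1`, compound 2 `O=[N+]([O-])c1ncn(CCCNS(=O)(=O)Cc2ccccc2)n1` and compound 3 `Cn1ccnc1S(=O)(=O)NCCn1cnc([N+](=O)[O-])n1`. In an ADME assay on L6 cells (Rattus norvegicus) for cytotoxicity (on this read-out higher numbers stand for weaker inhibition and lower numbers for stronger inhibition), compound 1 gives only a limit, > 321000 nM. In this assay compound 2 gives only a limit, > 307000 nM. In this assay compound 3 gives only a limit, > 332000 nM.

Compound 1 and compound 3 differ by a single change, (1-methyl-1H-imidazol-2-yl in place of benzyl on a sulfonyl sulfur). The step that the two limits leave unreadable from compound 1 to compound 3 has no readable size because the limit of > 321000 nM in this assay, at which 1 of the 3 values shown sits, and the limit of > 332000 nM in this assay, at which 1 of the 3 values shown sits, are both limits of the assay rather than numbers. The difference between the cores of compound 1 and compound 2 is not broken down here.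

Compound 4 `Cn1ccnc1S(=O)(=O)NCCCn1cnc([N+](=O)[O-])n1` is not yet measured. It stands to compound 2 as compound 3 stands to compound 1, by the same change, (1-methyl-1H-imidazol-2-yl in place of benzyl on a sulfonyl sulfur), at a place described in the same words for both pairs. Compound 2 itself sits at the limit of > 307000 nM in this assay, at which 1 of the 3 values shown sits. The step from compound 2 to compound 4 is expected to be about a step that the limit leaves unreadable from compound 2 to compound 4, and this expectation rests only on a step that the two limits leave unreadable from compound 1 to compound 3 being unreadable and on compound 2 sitting at the limit of > 307000 nM in this assay, at which 1 of the 3 values shown sits. Compound 4 is therefore estimated at 500000 nM, within a range from 200000 nM to 2000000 nM, and most probably only a limit will again be reported.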

Compound 4, half-maximal inhibitory concentration: > 317000 nM
Compound 4: no number, only a limit; the forecaster's own chance of this, stated with the estimate: 85%; the middle value does not contradict the limit.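

In this assay, compound 2 and compound 4 each give only a limit of the assay rather than a number, and the size of the step between them cannot be read. The compounds shown leave open at what concentration any of them would inhibit these cells, and whether 1-methyl-1H-imidazol-2-yl in place of benzyl changes that concentration at all.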